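The source may report more compounds than this note shows. Statements on the series, on what has been measured and on what is new or still open speak of the compounds shown alone.

Of the compounds shown here, three that share one core have been tested in a functional assay on K562 cells (Homo sapiens), read by MTT assay, with a stated time of 72 h; on this read-out lower numbers stand for stronger inhibition and higher numbers for weaker inhibition: compound 1 (`CNc1ncnc2c1c(-c1ccoc1)cn2[C@@H]1O[C@H](CO)[C@@H](O)[C@H]1O`), compound 2 (`CNc1ncnc2c1c(-c1cccs1)cn2[C@@H]1O[C@H](CO)[C@@H](O)[C@H]1O`) and compound 3 (`CNc1ncnc2c1c(-c1ccsc1)cn2[C@@H]1O[C@H](CO)[C@@H](O)[C@H]1O`). Compound 1 gives > 20000 nM here, which is a limit of the assay and not a number. Compound 2 gives > 20000 nM here, again a limit. Compound 3 gives > 20000 nM here, also a limit. The set therefore stands at the limit of > 20000 nM in this assay, at which 3 of the 3 values shown sit, and offers no true number as a starting point.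

The next compound is compound 4 (`C#Cc1cn([C@@H]2O[C@H](CO)[C@@H](O)[C@H]2O)c2ncnc(NC)c12`), which carries ethynyl in place of thiophen-3-yl on an aromatic carbon. Among the compounds with values here, three measured steps bear on this change: a step that the two limits leave unreadable from compound 1 to compound 2, a step that the two limits leave unreadable from compound 1 to compound 3 and a step that the two limits leave unreadable from compound 2 to compound 3. None of them has a readable size. They also only trade one five-membered aromatic ring for another, while ethynyl has no ring, so they are weak guides. Still, no ring tried so far has left the limit, so a further limit for compound 4 is the likeliest outcome, and any real number would probably lie not far under it. The expected change is an at least 1.3-fold lower number from compound 3 to compound 4 (0.12 log units; that floor lies within the scatter) and, if it can be read at all, it should point toward stronger inhibition. For compound 4 the estimated value is 15000 nM, with an expected range from 2000 nM to 30000 nM in this measurement.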

Compound 4, half-maximal inhibitory concentration: > 20000 nM
Compound 4 ended at the assay's limit (the forecaster's own chance of this, stated with the estimate: 60%); at least 1.3-fold (0.12 log units) between middle value and limit.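

Within the data shown here, compound 4 also gives a limit of the assay and not a number, so no step among compound 1, compound 2, compound 3 and compound 4 can be read in this assay. All four compounds end in the same place: the limit of > 20000 nM in this assay, at which 4 of the 4 values shown sit. The compounds shown leave open how weak each one truly is, and whether any group at this place on the shared core would give a real number.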